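Chain shortening at the aryl ether of the shared core

The source may report more compounds than this note shows. Statements on the series, on what has been measured and on what is new or still open speak of the compounds shown alone.

Measured compounds in an assay (Cricetulus griseus) for inhibition of aldehyde dehydrogenase, mitochondrial (Homo sapiens); a higher number here means a weaker inhibitor, a lower number a stronger inhibitor:
compound 1 `O=C(O)COc1ccc(-c2coc3cc(OCC(=O)O)ccc3c2=O)cc1` gives >> 9000 nM, which is a limit of the assay and not a number.
compound 2 `O=c1c(-c2ccc(O)cc2)coc2cc(OCCCCCCCCCO)ccc12` gives 700 nM.
compound 3 `CCCCCCC(Oc1ccc2c(=O)c(-c3ccc(O)cc3)coc2c1)C(=O)O` gives 2000 nM.

Compound 2 holds the lowest of the two numbers actually read in this assay; compound 3 sits a good deal higher, and that gap lies beyond the usual scatter. Compound 1 contributes only a limit, as stated in the limit of >> 9000 nM in this assay, at which 1 of the 3 values shown sits. For the measured compounds named here, no two measured compounds differ in a single place, so no measured step is available to calibrate the change at hand.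

Compound 4 `C=CCCCCOc1ccc2c(=O)c(-c3ccc(O)cc3)coc2c1` is the next compound for this assay. Against compound 2 the difference is vinyl in place of 5-hydroxypentyl on a saturated chain carbon, four bonds along the chain from an oxygen on an aromatic ring.

Going by the values given here, with no measured step of this kind, the expectation is a modest move, if any, toward a higher number. Compound 4 is expected to give about 1500 nM, with a plausible span from 400 nM to 5000 nM. The step that this estimate implies, a 2.1-fold higher number from compound 2 to compound 4 (0.33 log units; beyond the scatter), is expected to be small and may well fall within the scatter.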

Compound 4, half-maximal inhibitory concentration: 150 nM
The estimate for compound 4 lay 10-fold (1.00 log units) above the measured number, and the stated range ends above it.
By their numbers in this assay, from the lowest: compound 4; then compound 2; then compound 3. At a limit, above all of these: compound 1.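

In this assay, the saturated chain carbon four bonds along from the oxygen on an aromatic ring accepts a much shorter substituent without loss: vinyl in place of 5-hydroxypentyl gives a 4.7-fold lower number from compound 2 to compound 4 (0.67 log units; beyond the scatter). The long chain ending in a hydroxyl group of compound 2 is therefore not needed for a reading in this range, and the part that enters compound 4 carries neither a hydrogen-bond donor nor a hydrogen-bond acceptor. Nothing among the measurements shown accounts for the size of this step.

The step changes several things at once, with the chain length, the hydroxyl group and the double bond all differing, so the share of each stays unresolved. A saturated hexyl chain would separate the double bond from the chain length, while a shorter chain ending in hydroxyl or an amine at the chain end would show how the terminal group behaves at the length of compound 4.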